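The source may hold more compounds than are shown below. What is called first, only, known or untested is meant among the compounds shown, and "the series" means these compounds.

Working notes on the shared core of compound 1 `C/C=C/C(=O)Nc1cccc(-c2nc3ccccc3s2)c1`. In an ADME assay on HepG2 cells (Homo sapiens) for inhibition, with a stated time of 72 h (on this read-out lower numbers stand for an effect already at smaller amounts and higher numbers for an effect only at larger amounts of compound), compound 1 is reported only as a limit of the assay, > 25000 nM. Compound 2 `C=C(C)C(=O)Nc1cccc(-c2nc3ccccc3s2)c1` is likewise given only as a limit in this assay, > 25000 nM. Compound 3 `O=C(O)/C=C/C(=O)Nc1cccc(-c2nc3ccccc3s2)c1` also stops at a limit, > 25000 nM. With all three values at a limit, none of the steps among them can be sized: a step that the two limits leave unreadable from compound 1 to compound 2; a step that the two limits leave unreadable from compound 1 to compound 3; a step that the two limits leave unreadable from compound 2 to compound 3. The one firm point in the measured set is the limit of > 25000 nM in this assay, at which 3 of the 3 values shown sit.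

Going by the values given here, the step under consideration leads to compound 4 `CC(Cl)C(=O)Nc1cccc(-c2nc3ccccc3s2)c1`. 1-chloroethyl in place of prop-1-en-1-yl on a carbonyl carbon None of the measured steps involves 1-chloroethyl; the three that exist are unreadable and give no direction or size for this change. The expectation therefore rests on the measured set as a whole, where compound 1 sits at the limit > 25000 nM and no variant of the acyl group has yet produced a number. Compound 4 is expected to give a result of the same kind, with a step that the limit leaves unreadable from compound 1 to compound 4 estimated as essentially flat. The estimate for compound 4 is 30000 nM, with a range from 8000 nM to 100000 nM, and a high chance that this assay again reports only a limit.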

Compound 4, half-maximal effective concentration: > 25000 nM
Compound 4 gave a limit, no number (the forecaster's own chance of this, stated with the estimate: 80%); the middle value is on the limit's open side.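

Compound 4 is again only a limit in this assay, > 25000 nM. Going by these compounds alone, its steps from compound 1, compound 2 and compound 3 cannot be read, so no new step follows. The compounds shown leave open whether any group on the carbonyl carbon of the shared core gives a measurable value, and the only firm point remains (the limit of > 25000 nM in this assay, at which 4 of the 4 values shown sit)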